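This account rests on a few compounds, and the source may have more. Where it says the series, first, only, none or still open, it means among the compounds named here.

Compound 2 `COc1nc2ccccc2cc1/C=C/c1noc(-c2cccc(Cl)c2)n1` has been tested only in an ADME assay on HepG2 cells (Homo sapiens) for cytotoxicity, read by sulforhodamine B assay, with a stated time of 48 h; on this read-out lower numbers stand for higher toxicity in this test and higher numbers for lower toxicity in this test. In this assay compound 2 gives > 220000 nM, which is a limit of the assay rather than a measured number. Its closest relative, compound 1 `COc1nc2ccccc2cc1/C=C/c1noc(-c2ccc(Br)cc2)n1`, differs from it only in the aromatic group attached to the shared core. In this assay compound 1 gives > 195000 nM, again a limit and not a number. The size of the step between these two compounds cannot be read, because both values sit at limits (the limit of > 195000 nM in this assay, at which 1 of the 2 values shown sits, and (the limit of > 220000 nM in this assay, at which 1 of the 2 values shown sits)); it is recorded as a step that the two limits leave unreadable from compound 1 to compound 2.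

Compound 3 `COc1nc2ccccc2cc1/C=C/c1noc(/C=C/c2ccccc2)n1` is not yet measured. It carries 2-phenylethenyl in place of 3-chlorophenyl on an aromatic carbon. Among the measured compounds shown here, the one measured step bears on this change in that it also exchanges the group on the same aromatic carbon of the shared core, and it reached neither limit. The expected step from compound 2 to compound 3 in this assay is therefore a number no higher from compound 2 to compound 3 (the limit leaves the size open), nothing that a measurement of this kind would reveal. Compound 3 is expected to give around 220000 nM in this assay, within 150000 nM to 300000 nM, and most likely again only as a limit.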

Compound 3, half-maximal cytotoxic concentration: > 225000 nM
Compound 3: only a limit was reported (the forecaster's own chance of this, stated with the estimate: 85%); middle value at least 1.0-fold (0.00 log units) from the limit.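

Compound 3, like compound 1 and compound 2, gives only a limit of the assay in this assay, so neither the step from compound 1 to compound 3 nor the step from compound 2 to compound 3 can be read. The compounds shown leave open at what concentration, if any, each would harm the cells in this assay.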